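A few compounds are considered here, and "the series" means these few. Any claim that something is new, unique, unknown or untested is made for them only; others in the source may bear on it.

Measured compounds in an assay on CHO cells for antagonist activity at transient receptor potential cation channel subfamily V member 1 (Homo sapiens), read by FLIPR; on this read-out lower numbers stand for stronger inhibition and higher numbers for weaker inhibition:
compound 1 `CC(C(=O)NCc1ccc(C(F)(F)F)cc1N1CCCCCC1)c1ccc(NS(C)(=O)=O)c(F)c1` gives 1.6 nM;
compound 2 `CC(C(=O)NCc1ccc(C(F)(F)F)cc1N1CCCCCCC1)c1ccc(NS(C)(=O)=O)c(F)c1` gives 2.8 nM;
compound 3 `CCC1CCN(c2cc(C(F)(F)F)ccc2CNC(=O)C(C)c2ccc(NS(C)(=O)=O)c(F)c2)CC1` gives 0.7 nM.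

Compound 3 has the lowest number of the three, with both steps to it beyond the scatter: a 2.3-fold lower number from compound 1 to compound 3 (0.36 log units; beyond the scatter) and a 4.0-fold lower number from compound 2 to compound 3 (0.60 log units; beyond the scatter). The ring-size step a 1.8-fold higher number from compound 1 to compound 2 (0.24 log units; within the scatter) stays within the scatter.

Compound 4 `CC(C(=O)NCc1ccc(C(F)(F)F)cc1N1CCN(c2ccccc2)CC1)c1ccc(NS(C)(=O)=O)c(F)c1` differs from compound 3 by 4-phenylpiperazin-1-yl in place of 4-ethylpiperidin-1-yl on an aromatic carbon. Going by the values given here, no measured step covers a phenylpiperazine; the amine variations seen so far span only modest steps. A somewhat higher number than for compound 3 is expected in this assay, with wide uncertainty, as a 5.7-fold higher number from compound 3 to compound 4 (0.76 log units; beyond the scatter). For compound 4 the estimate is 4 nM, range 1 nM to 25 nM.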

Compound 4, inhibition constant: 2 nM
For compound 4 the middle estimate is 2.0-fold (0.30 log units) above the measured one; the range from low to high includes it.
By their numbers in this assay, from the lowest: compound 3; then compounds 1, 4 and 2 (each within the scatter of the next).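

In this assay, going by these compounds alone, the position ortho to a large group also takes the much larger 4-phenylpiperazin-1-yl: the only new step beyond the scatter is the one against 4-ethylpiperidin-1-yl, a 2.9-fold higher number from compound 3 to compound 4 (0.46 log units; beyond the scatter). Against the two simple rings the changes stay within the scatter, at a 1.4-fold lower number from compound 2 to compound 4 (0.15 log units; within the scatter) and a 1.3-fold higher number from compound 1 to compound 4 (0.10 log units; within the scatter), so an added phenyl ring on the piperazine is tolerated here. No evidence is available that bears on these steps. Still open, as far as these compounds go, is whether 4-benzylpiperidin-1-yl or 4-methylpiperazin-1-yl holds this level, and what a fluorine on the added phenyl ring does.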